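The source may report more compounds than this note shows. Statements on the series, on what has been measured and on what is new or still open speak of the compounds shown alone.

Compound 2 `COC[C@H]1OC(OCCc2ccccc2)[C@H](NC(=O)CCCN=C(N)N)[C@@H](OCc2ccc(Cl)cc2)[C@@H]1O` belongs to a small set of three measured sugar-based compounds sharing one core. In an assay on CHO cells for displacement of a labelled ligand from melanin-concentrating hormone receptor 1 (Homo sapiens), read by scintillation counting (on this read-out higher numbers stand for weaker inhibition and lower numbers for stronger inhibition), compound 2 gives 3500 nM. Compound 1 `COC[C@H]1OC(OCc2ccc(Cl)cc2)[C@H](NC(=O)CCCN=C(N)N)[C@@H](OCc2ccc(Cl)cc2)[C@@H]1O` gives 1200 nM in this assay, and compound 3 `COC[C@H]1OC(OCc2ccc3ccccc3c2)[C@H](NC(=O)CCN=C(N)N)[C@@H](OCc2ccc3ccccc3c2)[C@@H]1O` gives 6300 nM; the numbers of compound 2 and compound 3 lie within the scatter of each other, so no order between them can be read, while compound 1 sits clearly lower than compound 2.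

The unmeasured compound 4 `COC[C@H]1OC(OCc2ccc3ccccc3c2)[C@H](NC(=O)CCCN=C(N)N)[C@@H](OCc2ccc(Cl)cc2)[C@@H]1O` differs from compound 2 in one place: naphthalen-2-yl in place of benzyl on a saturated chain carbon bound to an oxygen on a saturated carbon. For the measured compounds named here, the one measured step at this position, a 2.9-fold higher number from compound 1 to compound 2 (0.46 log units; beyond the scatter), shows that exchanging an arylmethyl group for a benzyl group there raised the number modestly; compound 4 restores an arylmethyl group, so a step back towards lower numbers is expected, though the exact group is not the same as in compound 1. The expected step for compound 4 is therefore a 2.3-fold lower number from compound 2 to compound 4 (0.37 log units; beyond the scatter), and compound 4 is estimated at 1500 nM in this assay, with a range from 500 nM to 5000 nM.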

Compound 4, inhibition constant: 1800 nM
Estimate against measurement, compound 4: 1.2-fold (0.08 log units) below; measured number inside the range.
By their numbers in this assay, from the lowest: compounds 1, 4, 2 and 3 (each within the scatter of the next, the first and the last beyond it).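

Putting naphthalen-2-yl at this place gives a 1.9-fold lower number from compound 2 to compound 4 (0.29 log units; within the scatter) and a 1.5-fold higher number from compound 1 to compound 4 (0.18 log units; within the scatter) in this assay. Compound 4 therefore cannot be told apart from either compound 1 or compound 2, although those two differ by more than the scatter, so the second aromatic ring of naphthalen-2-yl brings no readable gain or loss against either single-ring group. No measured information is available here to explain this result.

The compounds shown leave open whether an amine or a carboxylic acid at this place would give a number in the same range as these carbon-only aromatic groups. They also leave open whether a longer chain between the oxygen and the naphthalen-2-yl group would change the number beyond the scatter.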